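Replacing 2-methoxyphenyl by pyridin-4-yl in compound 4

The compounds below may be only part of what the source reports. "The series", "measured", "known", "first", "only" and "open" are said of these compounds alone.

compound 1 `O=C1NC(=S)S/C1=C\C=C\c1ccccc1OCc1ccccc1C(F)(F)F`: 40.8%
compound 2 `COc1ccccc1COc1ccccc1/C=C/C=C1\SC(=S)NC1=O`: 78.8%
compound 3 `O=C1NC(=S)S/C1=C\C=C\c1ccccc1OS(=O)(=O)c1ccccc1`: 64.2%

In an assay on isolated protein for inhibition of protein tyrosine phosphatase type IVA 3 (Homo sapiens), tested at 5 ug/mL (on this read-out higher numbers stand for more inhibition at the one concentration tested (going by the name of the read-out) and lower numbers for less inhibition), compound 2 stands highest of the three numbers, beyond the scatter from compound 3 and further still from compound 1. Compound 4 `O=C1NC(=S)S/C1=C\C=C\c1ccccc1OCc1ccncc1` differs from compound 2 in one place: pyridin-4-yl in place of 2-methoxyphenyl on a saturated chain carbon bound to an oxygen on an aromatic ring. Among the measured compounds shown here, the single measured step, a number 38 percentage points higher from compound 1 to compound 2 (beyond the scatter), changed a substituent on the retained aromatic ring rather than the ring itself, so no measured step speaks directly to exchanging that ring for pyridin-4-yl; it shows only that this arm of the molecule moves the read-out strongly. The step from compound 2 to compound 4 is therefore expected to be a moderate fall, a number 23.8 percentage points lower from compound 2 to compound 4 (beyond the scatter). Compound 4 is estimated at 55%, within 30% to 80%.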

Compound 4, a percentage reported as inhibition, at one concentration (the size of the read-out at that concentration, not a potency): 39.4%
For compound 4 the middle estimate is 15.6 percentage points above the measured one; low and high end bracket the measured number.
By their numbers in this assay, from the lowest: compounds 4 and 1 (each within the scatter of the next); then compound 3; then compound 2.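

In this assay, exchanging the ring itself gives a number 39.4 percentage points lower from compound 2 to compound 4 (beyond the scatter), so this arm responds to a change of the whole ring as well as to a change of the substituent on it. Compound 4 at 39.4% and compound 1 at 40.8% lie within the scatter of each other, so either change gives up the high number of compound 2. Nothing available explains the fall. The compounds shown leave open how an unsubstituted phenyl ring would read here. They also do not separate loss of the methoxy group from entry of the ring nitrogen, which pyridin-3-yl or a methoxy-bearing pyridine could help to address.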